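Iodo in Place of Trifluoromethyl: Compound 3 to Compound 4

The source may report more compounds than this note shows. Statements on the series, on what has been measured and on what is new or still open speak of the compounds shown alone.

Three measured compounds share one core. Compound 1 `Cc1ccccc1-n1nc(C)c2c1NC(=O)[C@H](C)S[C@@H]2c1ccc(Oc2ccccc2)cc1` carries a methyl on the outer aromatic ring and gives 1300 nM in an assay on isolated protein for agonist activity at Bile acid receptor (Homo sapiens), read by AlphaScreen, with a stated time of 30 min; on this read-out lower numbers stand for an effect already at smaller amounts and higher numbers for an effect only at larger amounts of compound. Compound 2 `COC(=O)c1cccc(-c2ccc([C@H]3S[C@@H](C)C(=O)Nc4c3c(C)nn4-c3ccccc3C)cc2)c1` carries a methyl ester on a different outer ring and is reported in this assay as "not active" (no number reported), without a number. Going by the values given here, compound 3 `Cc1nn(-c2ccccc2C(F)(F)F)c2c1C(c1ccc(Oc3ccccc3)cc1)SC(C)C(=O)N2` carries a trifluoromethyl on the outer ring and gives 2000 nM in this assay, the higher of the two numbers known, though the gap to compound 1 lies within the usual scatter of repeated measurements, so the two cannot be ranked.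

Compound 4 `Cc1nn(-c2ccccc2I)c2c1C(c1ccc(Oc3ccccc3)cc1)SC(C)C(=O)N2` differs from compound 3 in a single place: iodo in place of trifluoromethyl on an aromatic carbon. Among the compounds with values here, no measured pair in this set shows what such a swap does, so the expectation rests on compound 3 alone. The step from compound 3 to compound 4 is expected to be small, likely within the scatter, at no change at the digits printed from compound 3 to compound 4 (within the scatter). Compound 4 is therefore estimated to give 2000 nM in this assay, with a range from 700 nM to 6000 nM.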

Compound 4, half-maximal effective concentration: 1300 nM
Compound 4: the middle estimate sits 1.5-fold (0.19 log units) above what was measured, within the range that was stated.
By their numbers in this assay, from the lowest: compounds 1, 4 and 3 (each within the scatter of the next).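

In this assay, going by these compounds alone, the change from 2-(trifluoromethyl)phenyl to 2-iodophenyl gives a 1.5-fold lower number from compound 3 to compound 4 (0.19 log units; within the scatter), the first step in this set that isolates this position. A group of 4 heavy atoms gives way to a group of 1 heavy atom, yet the two compounds cannot be told apart on this read-out, so at this level of resolution the two groups are interchangeable here. No other measurement bears on this result, so the numbers offer no explanation for it.

As far as these compounds go, it remains open whether a group of a different kind on this aromatic carbon, such as an amine, a carboxylic acid or a longer chain like ethoxy, would shift the number beyond the scatter. From the compounds shown here alone, it is also open whether iodo in place of trifluoromethyl would give an equally small step with a different outer ring, such as the methyl ester-bearing ring of compound 2.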